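The source may report more compounds than this note shows. Statements on the series, on what has been measured and on what is new or still open speak of the compounds shown alone.

Working notes on the series. In a functional assay (muscle tissue) with Cavia porcellus as the target (a higher number here means that more compound is needed for the effect, a lower number that less compound is needed), compound 1 `COC(=O)C1=C(C)N=C(C)/C(=C(\O)OC)C1c1cc([N+](=O)[O-])ccc1O` gives 100 nM, compound 2 `COC(=O)C1=C(C)N=C(C)/C(=C(\O)OC)C1c1cccc([N+](C)(C)C)c1` gives 50100 nM, and compound 3 `COC(=O)C1=C(C)N=C(C)/C(=C(\O)OC)C1c1c(Cl)cccc1Cl` gives 1.91 nM. Compound 3 thus carries the lowest number of the three; the gap to compound 1 lies beyond the scatter, and the gap to compound 2 is far larger still. Compound 4 `COC(=O)C1=C(C)N=C(C)/C(=C(\O)OC)C1c1ccccc1C#N` has not yet been run in this assay. Its change from compound 3 is 2-cyanophenyl in place of 2,6-dichlorophenyl on a saturated ring carbon. Among the compounds with values here, no measured pair in the set isolates this particular swap on the saturated ring carbon, so the step is read from the size of the other changes. A moderate rise in the number from compound 3 to compound 4 is expected, a 7.9-fold higher number from compound 3 to compound 4 (0.90 log units; beyond the scatter), beyond the scatter. Compound 4 is estimated at 15 nM, within 3 nM to 80 nM.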

Compound 4, half-maximal effective concentration: 15.9 nM
Compound 4: the middle estimate sits 1.1-fold (0.03 log units) below what was measured; the measured number falls inside the stated range.
By their numbers in this assay, from the lowest: compound 3; then compound 4; then compound 1; then compound 2.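

In this assay, within the data shown here, 2-cyanophenyl in place of 2,6-dichlorophenyl on the saturated ring carbon gives an 8.3-fold higher number from compound 3 to compound 4 (0.92 log units; beyond the scatter), the first step in the set that isolates a change at this position. The number at this position thus responds to the aryl group, although this swap removes both chlorines and adds the nitrile at once, so neither part can be credited alone. No available measurement explains the step. A 2-chlorophenyl group would help separate these two parts. From the compounds shown here alone, the effect of a 2,6-dicyanophenyl group also remains open.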